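The source may hold more compounds than are shown below. What is called first, only, known or untested is meant among the compounds shown, and "the series" means these compounds.

Measured compounds:
compound 1 `CC(C)=CCC1Cc2c(O)cc(=O)n(CCCO)c2CC1(C)C` — 0%
compound 2 `CC(C)=CCC1Cc2c(OCCCNS(=O)(=O)c3ccc(Cl)cc3)cc(=O)n(CCCO)c2CC1(C)C` — 9.8%
compound 3 `CC(C)=CCC1Cc2c(OCCCNS(=O)(=O)c3ccc(Br)cc3)cc(=O)n(CCCO)c2CC1(C)C` — 3.7%

In a functional assay on PANC-1 cells (Homo sapiens) for inhibition, read by MTT assay, with a stated time of 24 h, tested at 10 uM (a higher number here means more inhibition at the concentration tested (going by the name of the read-out), a lower number less inhibition), compound 1 gives 0%, compound 2 gives 9.8% and compound 3 gives 3.7%. All three numbers lie close together: compound 3 differs from compound 1 and from compound 2 by less than the usual scatter, so none of the three can be set apart from the others. Within the data shown here, the one step among them, a number 6.1 percentage points lower from compound 2 to compound 3 (within the scatter), is likewise within the scatter.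

Compound 4 `CC(C)=CCC1Cc2c(OCCCNC(=O)c3ccco3)cc(=O)n(CCCO)c2CC1(C)C` arises from compound 3 by the change ((furan-2-yl)carbonyl in place of (4-bromophenyl)sulfonyl on an amine nitrogen). Among the measured compounds shown here, only one measured step exists, and it concerns a halogen swap on the same arm rather than the exchange of the whole group, so it bears on the present change only loosely; it showed no movement beyond the scatter, and nothing else in the data argues for a larger effect. Compound 4 is therefore expected to give about 4% in this assay, with a range from 0% to 14%. The corresponding step, a number 0.3 percentage points higher from compound 3 to compound 4 (within the scatter), is estimated to remain within the scatter.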

Compound 4, a percentage reported as inhibition, at one concentration (the size of the read-out at that concentration, not a potency): 4.3%
Compound 4: the middle estimate sits 0.3 percentage points below what was measured; the measured number falls inside the stated range.
By their numbers in this assay, from the lowest: compounds 1, 3, 4 and 2 (each within the scatter of the next).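

In this assay the exchange on the amine nitrogen shows a number 0.6 percentage points higher from compound 3 to compound 4 (within the scatter) when (furan-2-yl)carbonyl replaces (4-bromophenyl)sulfonyl and a number 5.5 percentage points lower from compound 2 to compound 4 (within the scatter) when it replaces (4-chlorophenyl)sulfonyl at the same place, so swapping the whole group, and not just its halogen, leaves the read-out within the scatter. Placing 3-(((furan-2-yl)carbonyl)amino)propyl in place of hydrogen on the oxygen gives a number 4.3 percentage points higher from compound 1 to compound 4 (within the scatter) as well, so this arm cannot be set apart from the unsubstituted core either. Nothing available bears on why these numbers stay together.

The compounds shown leave open whether any group at this nitrogen can move the read-out beyond the scatter. Also open, from the compounds shown here alone, is whether a carboxylic acid or a free amine at the end of the arm, or a longer chain, would do so.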